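The source may report more compounds than this note shows. Statements on the series, on what has been measured and on what is new or still open speak of the compounds shown alone.

Compound 1 `CC(C)=CCOc1cc(Nc2nccs2)ccc1Cl` gives 26000 nM
Compound 2 `CCCc1ccc(Nc2nccs2)cc1OCC=C(C)C` gives 23000 nM
Compound 3 `CC(C)=CCOc1cc(Nc2nccs2)ccc1C#N` gives 750 nM

All three values come from a functional assay on MT2 cells (Homo sapiens) for cytotoxicity, read by MTT assay; a higher number here means that more compound is tolerated, a lower number that less compound is tolerated. Compound 1 has the highest of the three numbers, although compound 2 cannot be told apart from it: a 1.1-fold lower number from compound 1 to compound 2 (0.05 log units; within the scatter). Only compound 3 clearly separates from compound 1: a 35-fold lower number from compound 1 to compound 3 (1.54 log units; beyond the scatter).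

Compound 4 `Clc1ccc(Nc2nccs2)cc1OCc1ccoc1` keeps the chloro group and the core of compound 1 but changes the ether chain: furan-3-yl in place of 2-methylprop-1-en-1-yl on a saturated chain carbon bound to an oxygen on an aromatic ring. In short, furan-3-yl stands in place of 2-methylprop-1-en-1-yl, on a saturated chain carbon bound to an oxygen on an aromatic ring.

Among the compounds with values here, no measured step touches that place. All three change a group on an aromatic carbon instead, so they offer only indirect guidance. They do show that one change can leave the number within the scatter, as in a 1.1-fold lower number from compound 1 to compound 2 (0.05 log units; within the scatter), while another can move it a long way, as in a 31-fold lower number from compound 2 to compound 3 (1.49 log units; beyond the scatter). Within the data shown here, with no direct precedent, no step beyond the scatter is expected in this assay, though the uncertainty is wide.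

The expected step is a 1.3-fold lower number from compound 1 to compound 4 (0.11 log units; within the scatter).

For compound 4 the estimated value is 20000 nM, with an expected range from 6000 nM to 60000 nM.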

Compound 4, half-maximal cytotoxic concentration: 26000 nM
Compound 4: the middle estimate sits 1.3-fold (0.11 log units) below what was measured; the measured number falls inside the stated range.
By their numbers in this assay, from the lowest: compound 3; then compounds 2, 1 and 4 (each within the scatter of the next).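

In this assay, the ether chain gives its first readable step, which is no change at the digits printed from compound 1 to compound 4 (within the scatter) for furan-3-yl in place of 2-methylprop-1-en-1-yl on a saturated chain carbon bound to an oxygen on an aromatic ring. Within the data shown here, an open chain with a double bond can therefore give way to a five-membered aromatic ring holding an oxygen without any visible effect on this number, which is new information, since the earlier steps all concerned a group on an aromatic carbon, including the large one, a 35-fold lower number from compound 1 to compound 3 (1.54 log units; beyond the scatter). Nothing measured here explains why the number holds steady across this swap.

This is a single replacement, so it remains unclear whether a phenyl group, a longer alkyl chain or a chain ending in an amine would fit at the same place with equally little effect. Going by these compounds, it also remains open whether the (furan-3-yl)methyl group would leave the number as undisturbed if cyano replaced chloro on the aromatic carbon, the change that separated compound 3 from compound 1.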